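Amide substituent swap: piperidin-2-yl for amino-methylethyl

The source may hold more compounds than are shown below. What is called first, only, known or untested is meant among the compounds shown, and "the series" means these compounds.

Compound 2 `COc1cccc2c1c(NS(=O)(=O)c1ccc(Cl)s1)nn2Cc1cccc(CNC(=O)C(C)(C)N)c1` gives 18 mL/min/kg in an ADME assay on the whole organism (strain Beagle) for pharmacokinetics, with Canis familiaris (Canis lupus familiaris) as the target, at a dose of 0.5 mg/kg by the intravenous route; on this read-out lower numbers stand for slow clearance and higher numbers for fast clearance; of the two numbers measured, it and compound 1 `CN[C@H](C)C(=O)NCc1cccc(Cn2nc(NS(=O)(=O)c3ccc(Cl)s3)c3c(OC)cccc32)c1` sit within the scatter of each other, compound 1 giving 17 mL/min/kg in this assay. Within the data shown here, the one measured step, a 1.1-fold higher number from compound 1 to compound 2 (0.02 log units; within the scatter), is flat. Compound 3 `COc1cccc2c1c(NS(=O)(=O)c1ccc(Cl)s1)nn2Cc1cccc(CNC(=O)[C@@H]2CCCCN2)c1` carries piperidin-2-yl in place of 1-amino-1-methylethyl on a carbonyl carbon. Among the measured compounds shown here, no measured step covers this exact change; the step from compound 1 to compound 2, also an exchange on the same carbonyl carbon, bears on it and was within the scatter, so no step beyond the scatter is expected, no change at the digits printed from compound 2 to compound 3 (within the scatter). Compound 3 is therefore expected to give 18 mL/min/kg, in the range 11 mL/min/kg to 30 mL/min/kg.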

Compound 3, clearance: 32 mL/min/kg
The estimate for compound 3 lay 1.8-fold (0.25 log units) below the measured number; measured number outside the range, above it.
By their numbers in this assay, from the lowest: compounds 1, 2 and 3 (each within the scatter of the next).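

In this assay, piperidin-2-yl in place of 1-amino-1-methylethyl on a carbonyl carbon stays within the scatter (a 1.8-fold higher number from compound 2 to compound 3 (0.25 log units; within the scatter)), as does piperidin-2-yl in place of 1-(methylamino)ethyl (a 1.9-fold higher number from compound 1 to compound 3 (0.27 log units; within the scatter)). This position therefore accepts a six-membered non-aromatic ring, as well as the two open-chain amino groups, with no step beyond the scatter. No data on the compounds explain these clearance numbers.

Still open, on these data alone, is whether a carboxylic acid or a longer alkyl chain on this carbonyl carbon would give a step beyond the scatter. As far as these compounds go, the other stereoisomer of the piperidin-2-yl group also remains open.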